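A few compounds are considered here, and "the series" means these few. Any claim that something is new, unique, unknown or untested is made for them only; others in the source may bear on it.

In a physicochemical assay for solubility, read by HPLC, in phosphate buffer, at pH 6.5 (on this read-out lower numbers stand for lower solubility and higher numbers for higher solubility), compound 2 `COC(=O)C1=C(CN2CCC(F)(F)CC2)NC(c2nccs2)=NC1(C)c1ccc(F)cc1` reads < 1 ug/mL as a limit of the assay and not a number. Compound 1 `COC(=O)C1=C(CN2CCCCC2)NC(c2nccs2)=NC1(C)c1ccc(F)cc1` gives 282 ug/mL in this assay and carries piperidin-1-yl at the same place. Going by the values given here, the one measured step runs an at least 280-fold lower number from compound 1 to compound 2 (2.45 log units; beyond the scatter) and is large and beyond the scatter, but it ends at a limit and so gives only a lower bound on its size. Among the compounds with values here, the change to compound 3 `COC(=O)C1=C(CN2CCCS2(=O)=O)NC(c2nccs2)=NC1(C)c1ccc(F)cc1` is a group of 7 heavy atoms (3 carbon, 1 nitrogen, 2 oxygen, 1 sulfur; one five-membered non-aromatic ring with 2 hetero atoms) in place of a group of 8 heavy atoms (5 carbon, 1 nitrogen, 2 fluorine; one six-membered non-aromatic ring with 1 hetero atom), on a saturated chain carbon bound to a double-bonded ring carbon and no measured step covers the entering group, so the step to compound 2 is the only guide. The estimated move is an at least 10-fold higher number from compound 2 to compound 3 (1.00 log units; beyond the scatter) in the direction of a higher number, of moderate size and beyond the scatter. Compound 3 is therefore estimated at 10 ug/mL with a range of 1.5 ug/mL to 70 ug/mL as the expected bounds.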

Compound 3, solubility: 125 ug/mL
Beside the measured number, compound 3's estimate is 13-fold (1.10 log units) below it; the whole stated range lies below it.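

In this assay, the low reading of compound 2 does not extend to every replacement of piperidin-1-yl on this saturated chain carbon bound to a double-bonded ring carbon: the change shows an at least 120-fold higher number from compound 2 to compound 3 (2.09 log units; beyond the scatter). Measured against piperidin-1-yl, the same entering group gives only a 2.3-fold lower number from compound 1 to compound 3 (0.35 log units; beyond the scatter), a modest step, so among the three groups shown, 4,4-difluoropiperidin-1-yl alone stands apart by a large step. The step from compound 2 gives only a lower bound on its size because compound 2 reads at a limit of the assay: the limit of < 1 ug/mL in this assay, at which 1 of the 3 values shown sits.

The compounds shown leave open whether a pyrrolidine or a morpholine on this carbon would read nearer to compound 1 or to compound 2. They also leave open whether an open-chain amine would keep the higher number.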